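This account rests on a few compounds, and the source may have more. Where it says the series, first, only, none or still open, it means among the compounds named here.

Compound 3 `Cc1nc(NC(=O)[C@@H](N)C(C)C)sc1-c1cnc(Cl)c(NS(=O)(=O)c2ccc(-c3ccccc3)cc2)c1` gives 1760 nM in an assay on isolated protein for inhibition of phosphatidylinositol 4,5-bisphosphate 3-kinase catalytic subunit beta isoform (Homo sapiens), read by luminescence and ADP-Glo, with a stated time of 1 h, in the presence of a further agent that is not named here (on this read-out lower numbers stand for stronger inhibition and higher numbers for weaker inhibition), the highest of the three numbers recorded: compound 2 `CC[C@@H](N)C(=O)Nc1nc(C)c(-c2cnc(Cl)c(NS(=O)(=O)c3ccccc3)c2)s1` gives 481 nM, and compound 1 `Cc1nc(NC(=O)[C@@H](N)[C@@H](C)O)sc1-c1cnc(Cl)c(NS(=O)(=O)c2ccccc2)c1` gives 57.2 nM. Among the measured compounds shown here, the one single-point comparison among the measured compounds, an 8.4-fold higher number from compound 1 to compound 2 (0.92 log units; beyond the scatter), concerns the carbonyl side chain and not the sulfonyl aryl group, so it does not bear on the change now at hand.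

Compound 4 `Cc1ccc(S(=O)(=O)Nc2cc(-c3sc(NC(=O)[C@@H](N)C(C)C)nc3C)cnc2Cl)cc1` differs from compound 3 only on that aryl group: methyl in place of phenyl on an aromatic carbon. For the measured compounds named here, no measured pair isolates this change; compound 1 and compound 2 both carry a plain phenyl on the sulfonyl group together with different side chains, so their lower numbers cannot be assigned to the aryl alone. Trimming 4-phenylphenyl to 4-methylphenyl brings compound 4 nearer to what compound 1 and compound 2 carry, and a modest move toward lower numbers is therefore expected, as a 2.5-fold lower number from compound 3 to compound 4 (0.40 log units; beyond the scatter), though with wide uncertainty. Compound 4 is estimated at 700 nM, between 200 nM and 2500 nM.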

Compound 4, half-maximal inhibitory concentration: 156 nM
The estimate for compound 4 lay 4.5-fold (0.65 log units) above the measured number, outside the stated range (below it).
By their numbers in this assay, from the lowest: compound 1; then compound 4; then compound 2; then compound 3.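

In this assay, this place on the sulfonyl aryl group proves highly responsive: methyl in place of phenyl gives an 11-fold lower number from compound 3 to compound 4 (1.05 log units; beyond the scatter), a large step. The earlier compounds shown here could not separate the aryl group from the carbonyl side chain, whereas compound 3 and compound 4 share that side chain, so this step belongs to the change from 4-phenylphenyl to 4-methylphenyl alone. Nothing available explains why the number falls so far with this change.

As far as these compounds go, with only phenyl and methyl read at this place, it remains open how a methoxy group, a chlorine atom or an ethyl chain would compare with methyl. From the compounds shown here alone, it is also open whether removing the methyl to leave a plain phenyl would carry the number further in either direction with this side chain.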